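This account rests on a few compounds, and the source may have more. Where it says the series, first, only, none or still open, it means among the compounds named here.

Compound 2 `Cc1cccc(/C=N/NC(=O)CSc2nnnn2-c2cccc3ccccc23)c1` in an ADME assay on MT4 cells (Homo sapiens) for cytotoxicity, read by MTT assay (on this read-out lower numbers stand for higher toxicity in this test and higher numbers for lower toxicity in this test), gives 269000 nM. Among the measured compounds shown here, this is the only number so far; the other entry is a limit. Compound 1 `O=C(CSc1nnnn1-c1cccc2ccccc12)N/N=C/c1ccc(Cl)cc1` in this assay gives > 295000 nM, which is a limit of the assay rather than a number. For the measured compounds named here, the only step measured in this assay, an at least 1.0-fold lower number from compound 1 to compound 2 (0.04 log units; that floor lies within the scatter), lies within the scatter.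

Compound 3 `COc1ccc(/C=N/NC(=O)CSc2nnnn2-c2cccc3ccccc23)cc1` differs from compound 2 by 4-methoxyphenyl in place of 3-methylphenyl on a carbon with a double bond to nitrogen. Going by the values given here, the one step that bears on it is the step from compound 1 to compound 2, and that step did not leave the scatter. Nothing in the series therefore points to a shift in this assay in either direction, and with the evidence that the limit of > 295000 nM in this assay, at which 1 of the 2 values shown sits, a value reported only as a limit remains possible. For compound 3 in this assay the expected step is a 1.0-fold higher number from compound 2 to compound 3 (0.00 log units; within the scatter). Compound 3 is accordingly estimated at 270000 nM, with a range from 130000 nM to 500000 nM.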

Compound 3, half-maximal cytotoxic concentration: > 298000 nM
Compound 3 gave a limit, no number; the forecaster's own chance of this, stated with the estimate: 40%; middle value at least 1.1-fold (0.04 log units) away from the limit.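

In this assay compound 3 gives > 298000 nM, which is a limit of the assay and not a number. The step with 4-methoxyphenyl in place of 3-methylphenyl on a carbon with a double bond to nitrogen is an at least 1.1-fold higher number from compound 2 to compound 3 (0.04 log units; that floor lies within the scatter), so no change beyond the scatter is shown, though none is excluded. Compound 1 and compound 3 both end in limits, and the step between them cannot be read.

As far as these compounds go, it remains open how far the true values of compound 1 and compound 3 lie past their limits, and whether any group at this place brings the number down beyond the scatter. An amine or a carboxylic acid on the phenyl ring, or a longer chain in place of methoxy, would test this.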